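The compounds below may be only part of what the source reports. "The series", "measured", "known", "first", "only" and "open" are said of these compounds alone.

Compound 1 `CC(C)N(Cc1cccc(OCCCCCC(=O)O)c1)C(=O)c1ccccc1` in an ADME assay on Raji cells (Homo sapiens) for cytotoxicity, read by CellTiter-Glo and resazurin assay, with a stated time of 72 h (a lower number here means that less compound is needed, a higher number that more compound is needed for the effect), gives > 26000 nM, a limit of the assay.
Compound 2 `CC(C)Oc1cccc(-c2ccc(C(=O)N(Cc3cccc(OCCCCCC(=O)O)c3)C(C)C)cc2)c1` in this assay gives > 26000 nM, also a limit.
Compound 3 `COc1cccc(-c2ccc(C(=O)N(Cc3cccc(OCCCCCC(=O)O)c3)C(C)C)cc2)c1` in this assay gives > 20900 nM, again a limit.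

Compound 3 thus stands only at a limit, and the other two values shown are limits as well, so no order among the three can be read. Compound 4 `Cc1nnc(-c2cccc(-c3ccc(C(=O)N(Cc4cccc(OCCCCCC(=O)O)c4)C(C)C)cc3)c2)o1` differs from compound 3 by 5-methyl-1,3,4-oxadiazol-2-yl in place of methoxy on an aromatic carbon. The steps that touch this position, a step that the two limits leave unreadable from compound 2 to compound 3 and a step that the two limits leave unreadable from compound 1 to compound 3, are both unreadable, since every value sits at a limit (the limit of > 20900 nM in this assay, at which 1 of the 3 values shown sits, (the limit of > 26000 nM in this assay, at which 2 of the 3 values shown sit)). No readable change is therefore expected in this assay; the step that the limit leaves unreadable from compound 3 to compound 4 is only an estimate. Compound 4 is expected near 30000 nM, within 10000 nM to 90000 nM, most likely reported again as a limit.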

Compound 4, half-maximal effective concentration: > 26000 nM
Compound 4: a limit, no number; the forecaster's own chance of this, stated with the estimate: 80%; the middle value lies beyond the limit too.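

Among the compounds shown here, compound 4 ends at a limit, as do compounds 1, 2 and 3, so no step between compound 4 and any of them can be read. The compounds shown leave open what concentration any of them needs for the effect in this assay.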